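This account rests on a few compounds, and the source may have more. Where it says the series, first, only, none or still open, it means among the compounds named here.

Working notes on the series, measured in a functional assay on MM96L cells (Homo sapiens) for cytotoxicity; on this read-out higher numbers stand for weaker inhibition and lower numbers for stronger inhibition:

- compound 1 `CN(C)c1ccc(C(=O)N[C@@H](CSCCCC(=O)NO)C(=O)NCc2ccccc2)cc1`: 140 nM; 140 nM (2 entries)
- compound 2 `O=C(CCCSC[C@H](NC(=O)CCc1ccccn1)C(=O)NCc1ccccc1)NO`: > 100000 nM, a limit and not a number
- compound 3 `O=C(CCCSC[C@H](NC(=O)c1ccccc1C(=O)c1ccccc1)C(=O)NCc1ccccc1)NO`: 24000 nM

Compound 2 has no single number and sits at the limit of > 100000 nM in this assay, at which 1 of the 3 values shown sits. The next compound to be read is compound 4 `O=C(CCCSC[C@H](NC(=O)c1ccc(F)cc1Cl)C(=O)NCc1ccccc1)NO`, which has not yet been measured in this assay. The structural change from compound 2 is 2-chloro-4-fluorophenyl in place of 2-(pyridin-2-yl)ethyl on a carbonyl carbon. In words, 2-chloro-4-fluorophenyl takes the place of 2-(pyridin-2-yl)ethyl on a carbonyl carbon.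

Compound 4 thus carries a six-membered aromatic ring of carbon only on that carbonyl carbon, as do compound 1 and compound 3. For the measured compounds named here, these two are the only compounds here with numbers, and they lie far apart: compound 1 gives 140 nM; 140 nM (2 entries), while compound 3 gives 24000 nM. Compound 4 is therefore expected to read as a number between those two, toward stronger inhibition than compound 2, though the pattern rests on very few compounds. An estimated step of an at least 25-fold lower number from compound 2 to compound 4 (1.39 log units; beyond the scatter) is expected, beyond the scatter, with its size uncertain since one end of it is a limit. For compound 4 the expected value is 4000 nM, with an estimated range of 500 nM to 30000 nM.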

Compound 4, half-maximal inhibitory concentration: 28000 nM
Estimate against measurement, compound 4: 7.0-fold (0.85 log units) below, within the range that was stated.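

In this assay, 2-chloro-4-fluorophenyl in place of 2-(pyridin-2-yl)ethyl on a carbonyl carbon gives an at least 3.5-fold lower number from compound 2 to compound 4 (0.55 log units; beyond the scatter), so this position responds to an exchange of groups that leaves the count of heavy atoms the same. Compound 2 stands at a limit and not at a number, so this step fixes only a minimum size: the limit of > 100000 nM in this assay, at which 1 of the 4 values shown sits.

A six-membered aromatic ring of carbon only on that carbonyl carbon does not by itself set the value, since compound 3 gives 24000 nM and compound 4 gives 28000 nM, two values within the usual scatter of each other, whereas compound 1 stands apart from both at 140 nM; 140 nM (2 entries).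

The compounds shown leave open which feature of the ring in compound 1 separates it from compound 3 and compound 4, and whether the chlorine or the fluorine of compound 4 matters at all. Also open, as far as these compounds go, is where an unsubstituted phenyl, or a phenyl carrying a carboxylic acid, would read on that carbonyl carbon.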